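The compounds below may be only part of what the source reports. "The series", "measured", "known", "first", "only" and "open" are said of these compounds alone.

Measured so far in a functional assay on HT-29 cells (Homo sapiens) for antiproliferative activity, read by sulforhodamine B assay, with a stated time of 72 h; on this read-out higher numbers stand for weaker inhibition and lower numbers for stronger inhibition:
compound 1 `S=C(N/N=C/c1ccc2ccccc2n1)Nc1cccc(Cl)c1` gives 48100 nM
compound 2 `COc1cccc(NC(=S)N/N=C/c2ccc3ccccc3n2)c1` gives 82400 nM
compound 3 `N#Cc1ccc(NC(=S)N/N=C/c2ccc3ccccc3n2)cc1` gives 15600 nM

Compound 3 has the lowest number of the three; its steps to the others, a 3.1-fold lower number from compound 1 to compound 3 (0.49 log units; beyond the scatter) and a 5.3-fold lower number from compound 2 to compound 3 (0.72 log units; beyond the scatter), both lie beyond the scatter, so it is the strongest inhibitor of this set. Compound 4 `S=C(N/N=C/c1ccc2ccccc2n1)Nc1ccccc1Br` is not yet measured. Its change from compound 3: 2-bromophenyl in place of 4-cyanophenyl on an amide-type nitrogen. Both measured steps bear on it, since each swapped a halogen- or methoxy-bearing phenyl for the 4-cyanophenyl and lowered the number; reversing that pattern, as compound 4 does, is expected to raise the number modestly, a 2.9-fold higher number from compound 3 to compound 4 (0.46 log units; beyond the scatter). Compound 4 is therefore estimated at 45000 nM, within 15000 nM to 130000 nM.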

Compound 4, half-maximal inhibitory concentration: > 100000 nM
Compound 4 ended at the assay's limit (the forecaster's own chance of this, stated with the estimate: 10%); at least 2.2-fold (0.34 log units) between middle value and limit.
By their numbers in this assay, from the lowest: compound 3; then compounds 1 and 2 (each within the scatter of the next). At a limit, above all of these: compound 4.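

In this assay compound 4 gives a limit of the assay and not a number: the limit of > 100000 nM in this assay, at which 1 of the 4 values shown sits.

On the amide-type nitrogen, 2-bromophenyl gives an at least 6.4-fold higher number from compound 3 to compound 4 (0.80 log units; beyond the scatter) and an at least 2.0-fold higher number from compound 1 to compound 4 (0.31 log units; beyond the scatter), so one halogen-bearing phenyl at this position does not predict another. The step of an at least 1.2-fold higher number from compound 2 to compound 4 (0.08 log units; that floor lies within the scatter) has a floor within the scatter and does not separate these two compounds.

The compounds shown leave open whether the change follows the bromine or its place on the phenyl. On these data alone, how an amine, a carboxylic acid or a longer chain would read at this position also remains open.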